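Chlorophenyl Rearrangement in the Paw Edema Series

A few compounds are considered here, and "the series" means these few. Any claim that something is new, unique, unknown or untested is made for them only; others in the source may bear on it.

In a functional assay on the whole organism (strain Wister albino) for inhibition, with Rattus norvegicus as the target, read by paw edema, with stated times of 30 min and 3 h, at a dose of 10 mg/kg by the oral route (on this read-out lower numbers stand for less inhibition and higher numbers for more inhibition at the one dose given (going by the name of the read-out)), compound 1 `CCOC(=O)C1CCN(Cn2nc(C(C)c3ccc(CC(C)C)cc3)oc2=S)CC1` gives 73.9%. Compound 2 `COc1ccc(N2CCN(Cn3nc(C(C)c4ccc(CC(C)C)cc4)oc3=S)CC2)cc1` gives 42.6%, and compound 3 `CC(C)Cc1ccc(C(C)c2nn(CN3CCN(c4ccc(Cl)cc4)CC3)c(=S)o2)cc1` gives 76.6%. Within the data shown here, compound 3 carries the largest of the three numbers; compound 1 sits within the scatter of it, while compound 2 lies well below, the single measured step being a number 34 percentage points higher from compound 2 to compound 3 (beyond the scatter). Compound 4 `CC(C)Cc1ccc(C(C)c2nn(CN3CCN(c4cccc(Cl)c4)CC3)c(=S)o2)cc1` differs from compound 3 by 3-chlorophenyl in place of 4-chlorophenyl on an amine nitrogen in a ring, the same atoms joined differently. Among the measured compounds shown here, no measured step touches such a rearrangement; the one step recorded swaps one group for another at the same place, so it bears on the present change only loosely. The expected step is therefore a number 8.6 percentage points lower from compound 3 to compound 4 (within the scatter), not beyond the scatter. Compound 4 is estimated at 68%, between 48% and 84%.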

Compound 4, a percentage reported as inhibition, in the whole organism at one dose (the size of the read-out at that dose, not a potency): 64.3%
Compound 4: middle estimate off by 3.7 percentage points, on the high side, and the stated range covers the measured number.
By their numbers in this assay, from the lowest: compound 2; then compounds 4, 1 and 3 (each within the scatter of the next, the first and the last beyond it).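

Where the chlorine sits on the phenyl group matters at this position: in this assay there is a number 12.3 percentage points lower from compound 3 to compound 4 (beyond the scatter) with no change in atoms. The 3-chlorophenyl group still keeps its advantage over the 4-methoxyphenyl group, with a number 21.7 percentage points higher from compound 2 to compound 4 (beyond the scatter) as the second step, so both chlorophenyl compounds stand beyond the scatter from compound 2. No measurement on hand explains either step. Open, on these data alone, is how a fluorophenyl, a bromophenyl or an unsubstituted phenyl group on the same ring nitrogen would compare with compound 3 and compound 4.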